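The compounds below may be only part of what the source reports. "The series", "measured", "known", "first", "only" and "open" are said of these compounds alone.

Measured compounds in a physicochemical assay for solubility, in phosphate buffer, measured as kinetic solubility, with a stated time of 18 h, at pH 7.4; a higher number here means a more soluble compound, a lower number a less soluble compound:
compound 1 `O=C(CCl)Nc1cccc(-c2nc3ccccc3s2)c1` gives 1000 nM;
compound 2 `O=C(Nc1cccc(-c2nc3ccccc3s2)c1)c1cnccc1Cl` gives 320 nM;
compound 3 `O=C(Nc1cccc(-c2nc3ccccc3s2)c1)c1cccnc1Cl` gives 520 nM.

Compound 3 stands within the scatter of both neighbours: nearest to compound 2, whose step a 1.6-fold higher number from compound 2 to compound 3 (0.21 log units; within the scatter) is within the scatter, and also close to compound 1, with a 1.9-fold lower number from compound 1 to compound 3 (0.28 log units; within the scatter). Among the measured compounds shown here, only the step of a 3.1-fold lower number from compound 1 to compound 2 (0.49 log units; beyond the scatter) lies beyond the scatter.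

Compound 4 `O=C(Nc1cccc(-c2nc3ccccc3s2)c1)c1ccnc(Cl)c1` differs from compound 3 by 2-chloropyridin-4-yl in place of 2-chloropyridin-3-yl on a carbonyl carbon. For the measured compounds named here, the one measured step that bears on this, a swap of one chloropyridinyl isomer for another, is a 1.6-fold higher number from compound 2 to compound 3 (0.21 log units; within the scatter), within the scatter. Compound 4 is therefore expected to show no step beyond the scatter, an estimated 1.2-fold lower number from compound 3 to compound 4 (0.06 log units; within the scatter). Compound 4 is expected to give about 450 nM, with a range from 200 nM to 1100 nM.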

Compound 4, solubility: 740 nM
Compound 4: the middle estimate sits 1.6-fold (0.22 log units) below what was measured; low and high end bracket the measured number.
By their numbers in this assay, from the lowest: compounds 2, 3, 4 and 1 (each within the scatter of the next, the first and the last beyond it).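

Among the compounds shown here, with a 1.4-fold higher number from compound 3 to compound 4 (0.15 log units; within the scatter) in this assay, this swap of 2-chloropyridin-3-yl for 2-chloropyridin-4-yl stays within the scatter, but a 2.3-fold higher number from compound 2 to compound 4 (0.36 log units; beyond the scatter) gives the first step between chloropyridinyl isomers beyond it. At this place on the carbonyl carbon, the isomer can therefore matter, though only for some pairs, while a 1.4-fold lower number from compound 1 to compound 4 (0.13 log units; within the scatter) leaves the 2-chloropyridin-4-yl amide within the scatter of the chloromethyl amide. Nothing available explains this difference between isomers.

Going by these compounds, what an amine or a carboxylic acid in place of the chlorine would do remains open, as does whether these steps hold on another core.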